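Trifluoromethoxy to hydroxy in a two-compound series

A few compounds are considered here, and "the series" means these few. Any claim that something is new, unique, unknown or untested is made for them only; others in the source may bear on it.

In a functional assay on A549 cells (Homo sapiens) for inhibition, read by sulforhodamine B assay (a higher number here means a weaker inhibitor of growth, a lower number a stronger inhibitor of growth), compound 1 `Cc1ccc2[nH]c(-c3ccc(-c4ccc(-c5ccccc5)cc4)cc3)nc2c1` gives 3630 nM and compound 2 `Cc1ccc2[nH]c(-c3ccc(-c4ccc(-c5ccc(OC(F)(F)F)cc5)cc4)cc3)nc2c1` gives 3560 nM so the two stand level within the scatter. Among the measured compounds shown here, the only measured step, trifluoromethoxy in place of hydrogen on an aromatic carbon, shows a 1.0-fold lower number from compound 1 to compound 2 (0.01 log units; within the scatter) and stays within the scatter. Compound 3 `Cc1ccc2[nH]c(-c3ccc(-c4ccc(-c5ccc(O)cc5)cc4)cc3)nc2c1` comes next, with the change hydrogen in place of trifluoromethyl on an oxygen on an aromatic ring that puts hydrogen in place of trifluoromethyl on an oxygen on an aromatic ring. For the measured compounds named here, no measured compound yet carries hydroxy, so that single step is a thin guide. Given that compound 2 sits at 3560 nM with the step from hydrogen flat, no shift beyond the scatter is expected in this assay at this stage. The estimated step is a 1.2-fold lower number from compound 2 to compound 3 (0.07 log units; within the scatter) and nothing larger is expected. Compound 3 is estimated at 3000 nM with an expected range of 1300 nM to 7000 nM as a working figure.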

Compound 3, concentration for 50% growth inhibition: 3520 nM
Estimate against measurement, compound 3: 1.2-fold (0.07 log units) below; low and high end bracket the measured number.
By their numbers in this assay, from the lowest: compounds 3, 2 and 1 (each within the scatter of the next).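

In this assay the position on the outer aromatic ring has now taken hydroxy as well as hydrogen and trifluoromethoxy, and removing trifluoromethyl from the oxygen gives a 1.0-fold lower number from compound 2 to compound 3 (0.00 log units; within the scatter) with no shift beyond the scatter. The step of a 1.0-fold lower number from compound 1 to compound 3 (0.01 log units; within the scatter) reads the same way, so hydroxy in place of hydrogen on an aromatic carbon also leaves the number level, and all three compounds stand together. No supporting data bear on why this position stays flat across these three groups.

From the compounds shown here alone, whether an amine, a carboxylic acid or a longer alkoxy chain such as butoxy at this position would also stay level remains open. The compounds shown also leave open whether this flat reading holds when the shared core itself is changed.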